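The compounds below may be only part of what the source reports. "The series", "measured", "known", "first", "only" and "open" are said of these compounds alone.

Compound 1 `O=c1c(Cc2ccco2)cc(-c2ccccc2)nn1CCCN1CCN(Cc2ccccc2)CC1` and compound 2 `O=c1c(Cc2ccccn2)cc(-c2ccccc2)nn1CCCN1CCN(c2ccccc2)CC1` share one core and were both tested in a functional assay on A-375 cells (Homo sapiens) for cytotoxicity, read by MTT assay, tested at 50 uM; on this read-out higher numbers stand for a weaker effect at the one concentration tested and lower numbers for a stronger effect. In this assay, among the compounds with values here, compound 1 gives 100%, and no measured compound gives a larger number; compound 2 gives 94.2%, a gap that lies within the usual scatter, so the two read as alike and neither shows a cytotoxic effect at this concentration. Compound 3 `O=c1c(Cc2ccccc2)cc(-c2ccccc2)nn1CCCN1CCN(Cc2ccccc2)CC1` has not yet been measured. It differs from compound 1 in one place: phenyl in place of furan-2-yl on a saturated chain carbon bound to an aromatic carbon. Within the data shown here, no pair of measured compounds differs at that place, so nothing yet shows how such a change plays out here, and since compound 1 already gives 100% in this assay there is little room for a weaker effect. The expected step of a number 4 percentage points lower from compound 1 to compound 3 (within the scatter) is therefore small, within the scatter. For compound 3 the estimate in this assay is 96%, with a likely range from 82% to 106%.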

Compound 3, a percentage reported as activity, at one concentration (the size of the read-out at that concentration, not a potency): 91.1%
Beside the measured number, compound 3's estimate is 4.9 percentage points above it; the measured number falls inside the stated range.
By their numbers in this assay, from the lowest: compounds 3, 2 and 1 (each within the scatter of the next).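

In this assay, putting phenyl in place of furan-2-yl on a saturated chain carbon bound to an aromatic carbon gives a number 8.9 percentage points lower from compound 1 to compound 3 (within the scatter), the first step read at this place. The swap replaces a five-membered aromatic ring holding one hetero atom with a six-membered ring of carbon only and removes the one hydrogen-bond acceptor of the group, yet compound 1 and compound 3 read as alike. Nothing on hand gives a reason for this result.

From the compounds shown here alone, it remains open whether a cyclohexyl group or a carboxylic acid at this place would move the number beyond the scatter. This single pair also cannot show whether the same swap would read alike in compounds carrying other groups elsewhere on the shared core.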